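Fluoro to Bromo in a Narrow Cytotoxicity Series

The source may report more compounds than this note shows. Statements on the series, on what has been measured and on what is new or still open speak of the compounds shown alone.

In a functional assay on MCF7 cells (Homo sapiens) for cytotoxicity, read by XTT assay, with a stated time of 24 h (on this read-out higher numbers stand for weaker inhibition and lower numbers for stronger inhibition), compound 3 `Cc1cc(O)c2c(c1F)C(=O)C=CC2=O` gives 20300 nM. That value lies within the scatter of the other two measured compounds, compound 1 `CCOc1cc(C)cc2c1C(=O)C=CC2=O` at 23700 nM and compound 2 `Cc1cc(O)c2c(c1Cl)C(=O)C=CC2=O` at 15700 nM. Compound 4 `Cc1cc(O)c2c(c1Br)C(=O)C=CC2=O` has not yet been measured. It differs from compound 3 by bromo in place of fluoro on an aromatic carbon, with bromo in place of fluoro on an aromatic carbon, para to a hydroxy group. Going by the values given here, the one measured halogen exchange is a 1.3-fold higher number from compound 2 to compound 3 (0.11 log units; within the scatter), so no step beyond the scatter is expected in this assay. The estimated step is a 1.2-fold lower number from compound 3 to compound 4 (0.08 log units; within the scatter). Compound 4 is expected at 17000 nM, with an estimated range from 9000 nM to 30000 nM.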

Compound 4, half-maximal inhibitory concentration: 15500 nM
For compound 4 the middle estimate is 1.1-fold (0.04 log units) above the measured one, within the range that was stated.
By their numbers in this assay, from the lowest: compounds 4, 2, 3 and 1 (each within the scatter of the next).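

With bromo, three halogens can now be compared on the aromatic carbon para to a hydroxy group, and in this assay the steps are a 1.3-fold lower number from compound 3 to compound 4 (0.12 log units; within the scatter) and a 1.0-fold lower number from compound 2 to compound 4 (0.01 log units; within the scatter). Going by these compounds alone, the single earlier exchange covered only fluoro and chloro, whereas fluoro, chloro and bromo now cannot be told apart on this read-out. Nothing available explains this result.

From the compounds shown here alone, whether an amine or a carboxylic acid on this carbon would give a step beyond the scatter remains open. So does whether these halogens would also match in any other assay.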